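A few compounds are considered here, and "the series" means these few. Any claim that something is new, unique, unknown or untested is made for them only; others in the source may bear on it.

The study compares three measured analogues built on one shared core. Compound 1 `CC(O)(CSc1ccccc1C(F)(F)F)C(=O)Nc1ccc(S(F)(F)(F)(F)F)cc1`, compound 2 `CC(O)(CSc1ccccc1OC(F)(F)F)C(=O)Nc1ccc(S(F)(F)(F)(F)F)cc1` and compound 3 `CC(O)(COc1cccc(C(F)(F)F)c1)C(=O)Nc1ccc(S(F)(F)(F)(F)F)cc1` were each tested in a functional assay on CWR22R cells (Homo sapiens) for antiproliferative activity, read by propidium iodide staining, with a stated time of 96 h; a higher number here means a weaker inhibitor, a lower number a stronger inhibitor. In this assay compound 1 gives 13200 nM, compound 2 gives 15000 nM, and compound 3 gives 14600 nM. The change trifluoromethoxy in place of trifluoromethyl on an aromatic carbon produced a 1.1-fold higher number from compound 1 to compound 2 (0.06 log units; within the scatter). How the core of compound 3 differs from that of compound 1 is not broken down here; the two values lie within the scatter of each other. Compound 4 `CC(O)(COc1cccc(OC(F)(F)F)c1)C(=O)Nc1ccc(S(F)(F)(F)(F)F)cc1` is not yet measured. It arises from compound 3 by trifluoromethoxy in place of trifluoromethyl on an aromatic carbon, the same kind of change as in the measured pair, though there the place was ortho to a large group and here it is meta to a large group. Resting on a 1.1-fold higher number from compound 1 to compound 2 (0.06 log units; within the scatter), the expected step is a 1.1-fold higher number from compound 3 to compound 4 (0.04 log units; within the scatter). Compound 4 is therefore estimated at 16000 nM in this assay, with a likely range from 8000 nM to 32000 nM.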

Compound 4, half-maximal inhibitory concentration: 17300 nM
The estimate for compound 4 lay 1.1-fold (0.03 log units) below the measured number; the measured number falls inside the stated range.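

Trifluoromethoxy in place of trifluoromethyl gave a 1.2-fold higher number from compound 3 to compound 4 (0.07 log units; within the scatter) in this assay. The step carried from one core to the other with no difference that the data can resolve: the same change on two cores in this assay, a 1.1-fold higher number (0.06 log units; within the scatter) from compound 1 to compound 2 and a 1.2-fold higher number (0.07 log units; within the scatter) from compound 3 to compound 4, 1.0-fold (0.02 log units) apart, within the scatter of two such steps. Among these compounds, this shows only that the change leaves the number within the scatter on these two cores; it does not show that either group is the better one, or that the same would hold on any other core.

The compounds shown leave open whether a different group on that aromatic carbon, such as a nitrile, an amine or a carboxylic acid, would give a step beyond the scatter in this assay. They also leave open whether any change at that place would move the number at all.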